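This account rests on a few compounds, and the source may have more. Where it says the series, first, only, none or still open, it means among the compounds named here.

Measured compounds:
Compound 1, `CC[C@@H]1C(=O)N(C)c2cnc(-n3ccc4cc(C(=O)NC5CCCC5)ccc43)nc2N1C1CCCC1`; in a functional assay on NCI-H1975 cells (Homo sapiens) for antiproliferative activity, read by CCK-8 assay, with a stated time of 72 h (on this read-out higher numbers stand for weaker inhibition of growth and lower numbers for stronger inhibition of growth), compound 1 gives 856 nM.
Compound 2, `CCC1C(=O)N(C)c2cnc(-n3ccc4cc(C(=O)NC5CCCC5)ccc43)nc2N1c1ccn(C)n1`; in this assay compound 2 gives "not active" (no number reported), with no number given.

Compound 1 thus carries the only number shown; compound 2 stands beside it without a figure, so nothing about the size of a step between the two can be said. Compound 3, `CC[C@@H]1C(=O)N(C)c2cnc(-n3ccc4ccccc43)nc2N1C1CCCC1`, differs from compound 1 in one place: hydrogen in place of cyclopentylcarbamoyl on an aromatic carbon. The change removes an amide group carrying one hydrogen-bond donor and one hydrogen-bond acceptor and leaves a bare hydrogen. Going by the values given here, no measured pair shows what such a removal does here, so the expectation rests only on how much of the molecule is lost. The step of a 3.5-fold higher number from compound 1 to compound 3 (0.54 log units; beyond the scatter) is expected to go toward weaker inhibition and to lie beyond the usual scatter. Compound 3 is therefore estimated at 3000 nM in this assay, within a range from 900 nM to 10000 nM.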

Compound 3, concentration for 50% growth inhibition: 28300 nM
For compound 3 the middle estimate is 9.4-fold (0.97 log units) below the measured one; the measured number lies above the stated range.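

In this assay, the cyclopentylcarbamoyl group on this aromatic carbon proves to matter a great deal: replacing it with hydrogen gives a 33-fold higher number from compound 1 to compound 3 (1.52 log units; beyond the scatter), a large step toward weaker inhibition of growth. Going by these compounds alone, this is the first pair that differs in one place, and it shows that the remaining structure of compound 3 still gives a number, 28300 nM, but only a far weaker one. No measurement is available to explain the size of this loss.

The compounds shown leave open whether the amide link or the cyclopentyl ring accounts for the step, since only the whole group and hydrogen can be compared at this position. A simple primary carboxamide, a carboxylic acid or an N-methyl amide in the same place would help to separate these two parts.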